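An Amide Aryl Exchange and the Step It Should Bring

The source may report more compounds than this note shows. Statements on the series, on what has been measured and on what is new or still open speak of the compounds shown alone.

Of the compounds shown here, two built on a shared core have been measured in a functional assay on A549 cells (Homo sapiens) for antiproliferative activity, read by CCK-8 assay, with a stated time of 72 h; on this read-out higher numbers stand for weaker inhibition and lower numbers for stronger inhibition. Compound 1 `COc1cc(C(=O)Nc2ccc(C(=O)/C=C/c3nc(C)c(C)nc3C)cc2)cc(OC)c1OC` gives 7350 nM in this assay. Compound 2 `Cc1nc(C)c(/C=C/C(=O)c2ccc(NC(=O)c3ccc(F)cc3F)cc2)nc1C` gives 2450 nM in this assay. Compound 2 therefore stands with the lower of the two numbers, and its nearest neighbour, compound 1, lies higher by a margin beyond the usual scatter.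

Compound 3 `COc1cc(OC)cc(C(=O)Nc2ccc(C(=O)/C=C/c3nc(C)c(C)nc3C)cc2)c1` has not yet been measured. It differs from compound 2 in one place: 3,5-dimethoxyphenyl in place of 2,4-difluorophenyl on a carbonyl carbon. Within the data shown here, no measured pair shows exactly this exchange, so the expectation rests on the two numbers in hand. Because compound 1 gives 7350 nM, a number well above that of compound 2, the exchange is expected to move in the direction of weaker inhibition, by a step somewhat beyond the scatter but short of the full gap between compound 2 and compound 1. The step of a 2.0-fold higher number from compound 2 to compound 3 (0.31 log units; beyond the scatter) is thus expected to be a moderate loss. Compound 3 is expected to give about 5000 nM in this assay, with a likely range from 2000 nM to 12000 nM.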

Compound 3, half-maximal inhibitory concentration: 10200 nM
For compound 3 the middle estimate is 2.0-fold (0.31 log units) below the measured one, within the range that was stated.
By their numbers in this assay, from the lowest: compound 2; then compounds 1 and 3 (each within the scatter of the next).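

In this assay, putting 3,5-dimethoxyphenyl in place of 2,4-difluorophenyl on the carbonyl carbon whose other neighbour is the amide-type nitrogen gives a 4.2-fold higher number from compound 2 to compound 3 (0.62 log units; beyond the scatter), a modest loss and a single-place change that reaches beyond the scatter at this position. The second step, hydrogen in place of methoxy on an aromatic carbon, is a 1.4-fold higher number from compound 1 to compound 3 (0.14 log units; within the scatter), so in this read-out that change cannot be told apart from no change at all, and the two methoxy-bearing aryl groups stand together on the weaker side of the 2,4-difluorophenyl group. Nothing among the data given accounts for either step.

The compounds shown leave open whether both fluorine atoms of the 2,4-difluorophenyl group are needed to hold the lower number, or whether a single fluorine, a chlorine or a plain phenyl ring would hold it as well. They also leave open how an amine such as morpholine, or a carboxylic acid, carried on this aromatic ring would read in this assay.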